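The source may report more compounds than this note shows. Statements on the series, on what has been measured and on what is new or still open speak of the compounds shown alone.

Measured in a functional assay on HeLa cells (Homo sapiens); on this read-out higher numbers stand for an effect only at larger amounts of compound and lower numbers for an effect already at smaller amounts:
- compound 1 `CCOC(=O)c1cc(CCl)[nH]n1`: > 100 ug/mL (a limit)
- compound 2 `NC(=O)c1cc(CCl)[nH]n1`: > 100 ug/mL (a limit)

Neither entry is a true number. Compound 1 stands at a limit of this assay, > 100 ug/mL, and so gives a bound rather than a measured potency. Compound 2 shares that position: the limit of > 100 ug/mL in this assay, at which 2 of the 2 values shown sit. For the measured compounds named here, the one measured change, amino in place of ethoxy on a carbonyl carbon, is a step that the two limits leave unreadable from compound 1 to compound 2. Going by the values given here, it also concerns a different group from the one that changes next.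

Compound 3 `CCOC(=O)c1cc(CI)[nH]n1` keeps the rest of compound 1 but carries iodo in place of chloro on a saturated chain carbon bound to an aromatic carbon. Among the compounds with values here, no measured step covers this swap, so the data fix neither its size nor its direction. The only anchor is the limit of compound 1, > 100 ug/mL, so the expectation stays close to it and the range is wide. The expected change is an at least 1.2-fold lower number from compound 1 to compound 3 (0.09 log units; that floor lies within the scatter), a modest shift towards smaller amounts at most. For compound 3 the estimated value is 80 ug/mL, with an expected range from 20 ug/mL to 200 ug/mL.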

Compound 3, concentration for half-maximal effect: > 100 ug/mL
Compound 3: only a limit was reported; the forecaster's own chance of this, stated with the estimate: 55%; at least 1.2-fold (0.09 log units) between middle value and limit.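

No step can be read from compound 1 to compound 3, since both give only a limit and not a true number in this assay and the same holds across the compounds shown: the limit of > 100 ug/mL in this assay, at which 3 of the 3 values shown sit.

The compounds shown leave open how far each one lies past that limit, and whether either change, amino in place of ethoxy or iodo in place of chloro, shifts the effect at all.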